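A few compounds are considered here, and "the series" means these few. Any claim that something is new, unique, unknown or untested is made for them only; others in the source may bear on it.

Compound 3 `COc1cc(C(=O)c2ccc3c(ccn3Cc3ccc(/C=C/C(=O)NO)cc3)c2)cc(OC)c1OC` is the compound whose step is followed here. Within the data shown here, in an assay on isolated protein for inhibition of protein deacetylase HDAC6 (Homo sapiens) (a higher number here means a weaker inhibitor, a lower number a stronger inhibitor), compound 3 gives 143 nM, the second highest of the three numbers known. Compound 2 `COc1cc(C(=O)c2ccc3c(ccn3Cc3ccc(C(=O)NO)cc3)c2)cc(OC)c1OC` gives 1540 nM in this assay, and compound 1 `COc1ccc(C(=O)c2ccc3c(ccn3Cc3ccc(C(=O)NO)cc3)c2)cc1` gives 3.92 nM. Compound 4 `COc1ccc(C(=O)c2ccc3c(ccn3Cc3ccc(/C=C/C(=O)NO)cc3)c2)cc1` has not yet been measured in this assay. It differs from compound 3 in one place: 4-methoxyphenyl in place of 3,4,5-trimethoxyphenyl on a carbonyl carbon. Among the measured compounds shown here, no measured step covers exactly this change, but the two values of compound 1 and compound 2, which differ from each other only in the same exchange on the hydroxycarbamoyl-bearing scaffold, show a very much lower number for compound 1 with the 4-methoxyphenyl. For the measured compounds named here, the only measured step, an 11-fold lower number from compound 2 to compound 3 (1.03 log units; beyond the scatter), concerns a different place and does not bear directly on this exchange. A large drop in the number is therefore expected for compound 4, by roughly a 72-fold lower number from compound 3 to compound 4 (1.85 log units; beyond the scatter) in this assay. The estimate for compound 4 in this assay is 2 nM, with a range from 0.3 nM to 15 nM.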

Compound 4, half-maximal inhibitory concentration: 108 nM
Beside the measured number, compound 4's estimate is 54-fold (1.73 log units) below it, and the stated range ends below it.
By their numbers in this assay, from the lowest: compound 1; then compounds 4 and 3 (each within the scatter of the next); then compound 2.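

In this assay, the exchange of 3,4,5-trimethoxyphenyl for 4-methoxyphenyl on a carbonyl carbon gives a 1.3-fold lower number from compound 3 to compound 4 (0.12 log units; within the scatter) when 2-(hydroxycarbamoyl)ethenyl is present, whereas with hydroxycarbamoyl compound 1 gives 3.92 nM and compound 2 gives 1540 nM. Among these compounds, the effect of this exchange therefore depends on which of these two groups the compound carries, something the earlier compounds alone could not show. The other change also reverses direction with 4-methoxyphenyl present, giving a 28-fold higher number from compound 1 to compound 4 (1.44 log units; beyond the scatter), so the two changes do not act independently: the same change on two cores in this assay, an 11-fold lower number (1.03 log units; beyond the scatter) from compound 2 to compound 3 and a 28-fold higher number (1.44 log units; beyond the scatter) from compound 1 to compound 4, 300-fold (2.47 log units) apart, beyond the scatter of two such steps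

The compounds shown leave open whether this dependence extends to other groups on the carbonyl carbon, such as 3,4-dimethoxyphenyl or unsubstituted phenyl. They also do not tell how a longer chain ending in hydroxycarbamoyl would behave with either aryl group.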